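The compounds below may be only part of what the source reports. "The series", "measured", "known", "first", "only" and "open" are said of these compounds alone.

Measured in an ADME assay on the whole organism (Rattus norvegicus, strain Fischer 344) for pharmacokinetics, with a stated time of 8 h, at a dose of 3 mg/kg by the oral route; on this read-out lower numbers stand for lower exposure and higher numbers for higher exposure at the dose given:
- Compound 1 `Cc1cc(N2CCC[C@H](COCc3nc(C)no3)C2)c2c(N)c(C(N)=O)sc2n1`: 722 ng.h/mL
- Compound 2 `COC[C@H]1CCCN(c2ccnc3sc(C(N)=O)c(N)c23)C1`: 227 ng.h/mL
- Compound 3 `CCOCCOC[C@H]1CCCN(c2cc(C)nc3sc(C(N)=O)c(N)c23)C1`: 1350 ng.h/mL

Compound 2 gives the lowest of the three numbers, and its gaps to the other two lie beyond the scatter. Compound 4 `Cc1noc(COC[C@H]2CCCN(c3ccnc4sc(C(N)=O)c(N)c34)C2)n1` has 3-methyl-1,2,4-oxadiazol-5-yl in place of hydrogen on a saturated chain carbon bound to an oxygen on a saturated carbon. Among the compounds with values here, no measured pair isolates this addition. The nearest evidence is a 1.9-fold higher number from compound 1 to compound 3 (0.27 log units; within the scatter), where the same group gives way to ethoxymethyl, and that step stays within the scatter. Compound 1 carries the group, but its core differs from that of compound 2. Only a small rise, within the scatter, is therefore expected, as a 1.5-fold higher number from compound 2 to compound 4 (0.18 log units; within the scatter). For compound 4 the estimated value is 340 ng.h/mL, with an expected range of 120 ng.h/mL to 950 ng.h/mL.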

Compound 4, area under the concentration-time curve: 563 ng.h/mL
Beside the measured number, compound 4's estimate is 1.7-fold (0.22 log units) below it; the range from low to high includes it.
By their numbers in this assay, from the lowest: compound 2; then compounds 4, 1 and 3 (each within the scatter of the next, the first and the last beyond it).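

In this assay, the addition of 3-methyl-1,2,4-oxadiazol-5-yl on a saturated chain carbon bound to an oxygen on a saturated carbon can now be read directly (a 2.5-fold higher number from compound 2 to compound 4 (0.39 log units; beyond the scatter)), and this step lies beyond the scatter. With that group in place, hydrogen in place of methyl on an aromatic carbon stays within the scatter (a 1.3-fold lower number from compound 1 to compound 4 (0.11 log units; within the scatter)). Nothing available explains either step. Within the data shown here, whether an amine or a longer ether chain in place of 3-methyl-1,2,4-oxadiazol-5-yl would give a similar step remains open, as does how ethoxymethyl, seen only on the core of compound 1, would read on the core of compound 2.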